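Carboxy in Place of Hydroxy: an Expected Step

This account rests on a few compounds, and the source may have more. Where it says the series, first, only, none or still open, it means among the compounds named here.

compound 1 `Cc1c(C(=O)Nc2c(F)cc(-c3cccc(F)c3)cc2F)nc2ccc(C(F)(F)F)cc2c1O` — 46.3%
compound 2 `Cc1c(C(=O)Nc2ccc(-c3ccccc3)cc2)nc2ccccc2c1O` — 26.5%

In a functional assay on A-375 cells (Homo sapiens) for antiproliferative activity, read by MTT assay, with a stated time of 24 h, tested at 11.11 ug/mL (on this read-out lower numbers stand for a weaker effect and higher numbers for a stronger effect at the one concentration tested), compound 1 gives 46.3%. Compound 2 gives 26.5%. Of the two numbers, compound 2 stands lowest, and compound 1 lies higher by a margin beyond the scatter. Compound 3 `Cc1c(C(=O)Nc2ccc(-c3ccccc3)cc2)nc2ccccc2c1C(=O)O` differs from compound 2 by carboxy in place of hydroxy on an aromatic carbon. No measured pair among these compounds shows this change, so the data give no direction for it. The expected step is a number 1.5 percentage points lower from compound 2 to compound 3 (within the scatter), none beyond the scatter. Compound 3 is therefore estimated to give 25%, with a range from 5% to 45%.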

Compound 3, a percentage reported as inhibition, at one concentration (the size of the read-out at that concentration, not a potency): 20.3%
Beside the measured number, compound 3's estimate is 4.7 percentage points above it; the measured number falls inside the stated range.
By their numbers in this assay, from the lowest: compounds 3 and 2 (each within the scatter of the next); then compound 1.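

In this assay, within the data shown here, carboxy in place of hydroxy on the aromatic carbon opposite the ring nitrogen gives a number 6.2 percentage points lower from compound 2 to compound 3 (within the scatter), a direct reading of this change that the earlier compounds did not offer. At this position, ortho to a methyl group, the read-out does not separate the two groups, although carboxy brings more heavy atoms. No measurement shown here accounts for this result.

Going by these compounds, whether an amine or a nitrile at this position would read the same remains open. So does whether carboxy in place of hydroxy would give a similar step on the core of compound 1.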